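A few compounds are considered here, and "the series" means these few. Any claim that something is new, unique, unknown or untested is made for them only; others in the source may bear on it.

Working notes on the series. Within the data shown here, the core shared by the compounds carries a silyl ether on an oxygen on a saturated carbon, and the variation so far lies there. Compound 1 `C=C1CC[C@@H]2[C@](C)(CO[Si](C(C)C)(C(C)C)C(C)C)[C@H](O)CC[C@@]2(C)[C@@H]1C/C=C1/C(=O)OC[C@H]1O` and compound 2 `C=C1CC[C@@H]2[C@](C)(CO[Si](c3ccccc3)(c3ccccc3)C(C)(C)C)[C@H](O)CC[C@@]2(C)[C@@H]1C/C=C1/C(=O)OC[C@H]1O` have both been tested in a functional assay on P388 cells (Mus musculus) for cytotoxicity, read by sulforhodamine B assay; on this read-out higher numbers stand for an effect only at larger amounts of compound and lower numbers for an effect already at smaller amounts: compound 1 gives 0.88 uM, and compound 2 gives 0.68 uM. The two numbers lie within the usual scatter of each other, so on the present data compound 1 is not separated from compound 2, and no direction of change can be read between them. Compound 3 `C=C1CC[C@@H]2[C@](C)(CO[Si](C)(C)C(C)(C)C)[C@H](O)CC[C@@]2(C)[C@@H]1C/C=C1/C(=O)OC[C@H]1O` is not yet measured; it differs from compound 1 in one place: a group of 7 heavy atoms (6 carbon, 1 silicon; no ring) in place of a group of 10 heavy atoms (9 carbon, 1 silicon; no ring), on an oxygen on a saturated carbon. With the two silyl variants already at hand giving values within the scatter of each other, no step beyond the scatter is expected from compound 1 to compound 3 in this assay, and the expected step is a 1.1-fold higher number from compound 1 to compound 3 (0.06 log units; within the scatter). Compound 3 is therefore estimated at 1 uM, with a range from 0.3 uM to 3 uM.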

Compound 3, concentration for half-maximal effect: 8.39 uM
The estimate for compound 3 lay 8.4-fold (0.92 log units) below the measured number; the measured number lies above the stated range.
By their numbers in this assay, from the lowest: compounds 2 and 1 (each within the scatter of the next); then compound 3.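

In this assay the group on this oxygen on a saturated carbon turns out not to be freely exchangeable: the group of 7 heavy atoms (6 carbon, 1 silicon; no ring) in place of the group of 10 heavy atoms (9 carbon, 1 silicon; no ring) gives a 9.5-fold higher number from compound 1 to compound 3 (0.98 log units; beyond the scatter) on this measure. Among these compounds, compound 1 and compound 2 showed no separation, so only this step shows that the read-out responds to a change at this position. Nothing measured on the compounds at hand bears on what lies behind the step.

On these data alone, a single step sets no trend, and whether it follows the atom count or the particular arrangement of the silyl substituents stays open. Also open, as far as these compounds go, is how a free hydroxyl, an acetyl ester or an octyl ether on this oxygen would stand in this assay.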